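Phenyl for ethyl on the piperazine nitrogen of compound 2

The source may report more compounds than this note shows. Statements on the series, on what has been measured and on what is new or still open speak of the compounds shown alone.

Measured so far:
- compound 1 `Cn1c(-c2ccc(NC(=O)CSc3nc4cc(Cl)ccc4o3)cc2)nc(-c2ccccc2)c1-c1ccccc1` — 27.7%
- compound 2 `CCN1CCN(CC(=O)Nc2ccc(-c3nc(-c4ccccc4)c(-c4ccccc4)n3C)cc2)CC1` — 16.4%

Among the measured compounds shown here, in a functional assay on MCF7 cells (Homo sapiens) for cytotoxicity, read by MTT assay, with a stated time of 24 h, tested at 6.4 ug/mL (on this read-out lower numbers stand for a weaker effect and higher numbers for a stronger effect at the one concentration tested), compound 2 stands lowest of the two numbers; its nearest neighbour is compound 1, and the one step between them, a number 11.3 percentage points lower from compound 1 to compound 2 (beyond the scatter), lies beyond the scatter. That step exchanged the whole group on the saturated chain carbon bound to the carbonyl carbon, so it says nothing direct about a change inside the piperazine.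

Compound 3 `Cn1c(-c2ccc(NC(=O)CN3CCN(c4ccccc4)CC3)cc2)nc(-c2ccccc2)c1-c1ccccc1` differs from compound 2 by phenyl in place of ethyl on an amine nitrogen in a ring. For the measured compounds named here, no measured step shows this kind of exchange, and the group that leaves and the one that enters carry the same counts of donors, acceptors and charge. A step no larger than the scatter is therefore expected, in no settled direction, so compound 3 is estimated at 20%, with a range from 8% to 36%, which corresponds to an expected step of a number 3.6 percentage points higher from compound 2 to compound 3 (within the scatter).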

Compound 3, a percentage reported as activity, at one concentration (the size of the read-out at that concentration, not a potency): 37.7%
Beside the measured number, compound 3's estimate is 17.7 percentage points below it, outside the stated range (above it).
By their numbers in this assay, from the lowest: compound 2; then compounds 1 and 3 (each within the scatter of the next).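

In this assay, among the compounds shown here, the group on the amine nitrogen in the ring is the first site where a change can be read with the rest of the molecule held constant, and phenyl in place of ethyl gives a number 21.3 percentage points higher from compound 2 to compound 3 (beyond the scatter). The whole-group exchange gives a number 10 percentage points higher from compound 1 to compound 3 (within the scatter), so 4-phenylpiperazin-1-yl and (5-chloro-1,3-benzoxazol-2-yl)sulfanyl cannot be told apart on the saturated chain carbon, and the low number of compound 2 does not carry over to every piperazine of this kind. No measurement here accounts for the step on the ring nitrogen.

On these data alone, with only ethyl and phenyl on this nitrogen, it remains open whether the aromatic ring itself matters. A cyclohexyl or a benzyl at the same place would address that, and a phenyl bearing a chlorine or a methoxy group would show whether the entering ring tolerates further substitution.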